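A Halogen Swap on the Aryl Amine of Compound 3

A few compounds are considered here, and "the series" means these few. Any claim that something is new, unique, unknown or untested is made for them only; others in the source may bear on it.

Of the compounds shown here, three sharing one core have been tested in a functional assay on MDA-MB-231 cells (Homo sapiens) for antiproliferative activity, read by MTT assay, with a stated time of 48 h; a higher number here means a weaker inhibitor, a lower number a stronger inhibitor. Compound 1 `O=C(/C=C/c1ccccc1)Nc1cc2c(Nc3ccc(F)c(Cl)c3)ncnc2s1` gives 7600 nM, compound 2 `COc1ccc(/C=C/C(=O)Nc2cc3c(Nc4cc(Cl)cc(Cl)c4)ncnc3s2)cc1` gives 1970 nM, and compound 3 `O=C(/C=C/c1ccccc1)Nc1cc2c(Nc3cccc(Cl)c3F)ncnc2s1` gives 3930 nM. On these numbers compound 3 stands second highest of the three: the step of a 1.9-fold lower number from compound 1 to compound 3 (0.29 log units; within the scatter) lies within the scatter, and compound 2 sits a similar distance on the other side, also within the scatter, so the three cannot be ordered with confidence.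

Compound 4 `O=C(/C=C/c1ccccc1)Nc1cc2c(Nc3cc(Cl)cc(Cl)c3)ncnc2s1` has not yet been measured. It differs from compound 3 in one place: 3,5-dichlorophenyl in place of 3-chloro-2-fluorophenyl on a nitrogen on an aromatic ring. Among the compounds with values here, the only measured step at the same position is a 1.9-fold lower number from compound 1 to compound 3 (0.29 log units; within the scatter), where moving a fluorine around the ring left the number within the scatter. Compound 2 also carries a 3,5-dichlorophenyl on that nitrogen, though it differs at the other end of the molecule as well, and it gave 1970 nM. Taken together, these point to a small change at most, leaning toward a lower number, so the step expected here, a 1.5-fold lower number from compound 3 to compound 4 (0.18 log units; within the scatter), is expected to stay within or near the scatter. Compound 4 is estimated at 2600 nM, with a likely range from 1200 nM to 5600 nM.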

Compound 4, half-maximal inhibitory concentration: 11500 nM
Compound 4: middle estimate off by 4.4-fold (0.65 log units), on the low side; the whole stated range lies below it.
By their numbers in this assay, from the lowest: compounds 2, 3, 1 and 4 (each within the scatter of the next, the first and the last beyond it).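

In this assay, within the data shown here, the group on this nitrogen now shows a real effect: the change to 3,5-dichlorophenyl gives a 2.9-fold higher number from compound 3 to compound 4 (0.47 log units; beyond the scatter) and is the first step at this position to pass beyond the scatter, in the direction of a weaker inhibitor. The effect depends on which group is replaced, since the same 3,5-dichlorophenyl set against the 3-chloro-4-fluorophenyl of compound 1 gives only a 1.5-fold higher number from compound 1 to compound 4 (0.18 log units; within the scatter) and leaves those two compounds indistinguishable. The 3,5-dichlorophenyl group also does not account for the low number of compound 2. With that group held constant, hydrogen in place of methoxy gives a 5.8-fold higher number from compound 2 to compound 4 (0.77 log units; beyond the scatter) and this is the largest step yet seen, so the methoxy site matters at least as much as the nitrogen substituent in this pair.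

From the compounds shown here alone, it remains open whether the methoxy step carries over to compounds with other groups on the nitrogen, and what a hydroxyl or a dimethylamino group at the methoxy site would give. Nothing available here explains the shift at either place.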